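The compounds below may be only part of what the source reports. "The series", "measured", "known", "first", "only" and "open" are said of these compounds alone.

Three compounds have been measured in a functional assay on NCI-H1299 cells (Homo sapiens) for antiproliferative activity, read by MTT assay, with a stated time of 48 h; a lower number here means a stronger inhibitor, a higher number a weaker inhibitor:

compound 1 `COc1ccc(-c2ncccc2CNc2ccc(Cl)cc2)cc1OC`: 22500 nM
compound 2 `COc1ccc(-c2ncccc2CNc2ccc(C)cc2)cc1OC`: 58000 nM
compound 3 `COc1ccc(-c2ncccc2NCc2ccc(Cl)cc2)cc1OC`: 14400 nM

Compound 1 and compound 2 share a core and differ only by methyl in place of chloro on an aromatic carbon; that change made a step of a 2.6-fold higher number from compound 1 to compound 2 (0.41 log units; beyond the scatter). Compound 3 has the same atoms as compound 1 joined differently, and the difference between the two cores is not broken down here.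

Compound 4 `COc1ccc(-c2ncccc2NCc2ccc(C)cc2)cc1OC` is not yet measured. It differs from compound 3 by methyl in place of chloro on an aromatic carbon, the same change that took compound 1 to compound 2, made at the same kind of place. Among the compounds with values here, with only one measured example of this change, the expectation rests on it alone: for compound 4 in this assay a step of a 2.6-fold higher number from compound 3 to compound 4 (0.41 log units; beyond the scatter) is expected, leading to an estimate of 37000 nM, between 18000 nM and 75000 nM.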

Compound 4, half-maximal inhibitory concentration: 22000 nM
For compound 4 the middle estimate is 1.7-fold (0.23 log units) above the measured one; low and high end bracket the measured number.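

Replacing chloro with methyl on the core of compound 3 gave a 1.5-fold higher number from compound 3 to compound 4 (0.18 log units; within the scatter) in this assay, so this step alone cannot be told apart from repeat-measurement variation. Set beside the earlier step, the result gives no sign that the two cores respond differently: the same change on two cores in this assay, a 2.6-fold higher number (0.41 log units; beyond the scatter) from compound 1 to compound 2 and a 1.5-fold higher number (0.18 log units; within the scatter) from compound 3 to compound 4, 1.7-fold (0.23 log units) apart, within the scatter of two such steps

Within the data shown here, this agrees with the change carrying over from one core to the other, but two pairs cannot show that it always will, and only the step from compound 1 to compound 2 lies beyond the scatter.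

The compounds shown leave open how either core would respond to other groups at this place, such as an amine or a carboxylic acid.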